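This account rests on a few compounds, and the source may have more. Where it says the series, first, only, none or still open, it means among the compounds named here.

The measured compounds are compound 1 `O=C(COc1cccc2ccccc12)N/N=C/c1ccc(O)cc1` with 20 ug/mL in an ADME assay on HEL cells (Homo sapiens) for cytotoxicity (on this read-out lower numbers stand for higher toxicity in this test and higher numbers for lower toxicity in this test), compound 2 `O=C(COc1cccc2ccccc12)N/N=C/c1cccc(O)c1` with 100 ug/mL in this assay, and compound 3 `O=C(COc1cccc2ccccc12)N/N=C/c1ccc([N+](=O)[O-])cc1` with 20 ug/mL in this assay.

Compound 4 `O=C(COc1cccc2ccccc12)N/N=C/c1cccc([N+](=O)[O-])c1` has not been measured in this assay. It differs from compound 2 by nitro in place of hydroxy on an aromatic carbon. The same kind of change was made from compound 1 to compound 3, namely (nitro in place of hydroxy on an aromatic carbon), and there the step was no change at the digits printed from compound 1 to compound 3 (within the scatter). The two places are not identical: in compound 3 the nitro stands para to a large group, whereas in compound 4 it stands meta to a large group. The cores of compound 2 and compound 1 differ by 3-hydroxyphenyl in place of 4-hydroxyphenyl on a carbon with a double bond to nitrogen, and the step between them was a 5.0-fold higher number from compound 1 to compound 2 (0.70 log units; beyond the scatter), so compound 2 stands highest of the three numbers.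

Resting on the earlier step, compound 4 is expected to show no change at the digits printed from compound 2 to compound 4 (within the scatter) relative to compound 2 in this assay, because compound 3 gave no change at the digits printed from compound 1 to compound 3 (within the scatter) from compound 1. Compound 4 is estimated at 100 ug/mL in this assay, with a range from 30 ug/mL to 200 ug/mL.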

Compound 4, minimum cytotoxic concentration in the HEL assay: >= 20 ug/mL
Compound 4 ended at the assay's limit; the forecaster's own chance of this, stated with the estimate: 15%; the middle value does not contradict the limit.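

Going by these compounds alone, in the HEL assay compound 4 stands at a limit of the assay and not at a number, so no step from compound 2 to compound 4 can be read: the limit of >= 20 ug/mL in the HEL assay, at which 1 of the 4 values shown sits.

In a physicochemical assay for lipophilicity, measured as octanol-water partition (a lower number here means a more polar compound, a higher number a more lipophilic compound), compound 2 gives 3.73 and compound 4 gives 3.97, which is a number 0.24 log units higher from compound 2 to compound 4 (within the scatter).

Going by these compounds, in the HEL assay it stays open how far nitro in place of hydroxy moves the number when it stands meta to a large group.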